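Fluoro to methylsulfanyl on compound 2

The compounds below may be only part of what the source reports. "The series", "measured", "known", "first", "only" and "open" are said of these compounds alone.

In an in vitro ADME assay on microsomes from liver (Rattus norvegicus) for metabolic stability (a lower number here means slower removal, a higher number faster removal of the compound), compound 2 (`CNC[C@]1(O)Cc2ccccc2[C@@H]1Oc1ccccc1F`) gives <= 3 mL/min/kg as its reading, which is a limit of the assay and not a number. Compound 2 thus stands at the limit of <= 3 mL/min/kg in this assay, at which 1 of the 2 values shown sits, and has no exact place in the series. Compound 1 (`CNC[C@]1(O)Cc2ccccc2[C@@H]1Oc1ccccc1Cl`) gives 10 mL/min/kg as a plain number in this assay and is the only firm reference.

The next structure is compound 3 (`CNC[C@]1(O)Cc2ccccc2[C@@H]1Oc1ccccc1SC`), with methylsulfanyl in place of fluoro on an aromatic carbon and the shared core unchanged. Within the data shown here, one measured step bears on this change, fluoro in place of chloro on an aromatic carbon, which gave an at least 3.3-fold lower number from compound 1 to compound 2 (0.52 log units; beyond the scatter) and lies beyond the scatter. Going by these compounds, its full size stays open, as one end of it is a limit. Taken in reverse, that single step points to a higher number once fluoro leaves, so an upward step beyond the scatter is expected in this assay here. The estimated step is an at least 4.0-fold higher number from compound 2 to compound 3 (0.60 log units; beyond the scatter) on this reading. The estimate for compound 3 is 12 mL/min/kg within an expected range of 5 mL/min/kg to 30 mL/min/kg for this measurement.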

Compound 3, clearance: 43 mL/min/kg
Beside the measured number, compound 3's estimate is 3.6-fold (0.55 log units) below it, and the stated range ends below it.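

Working from the same position, on an aromatic carbon ortho to a large group, the series now has three substituents in this assay, and methylsulfanyl carries the highest number of the three: an at least 14-fold higher number from compound 2 to compound 3 (1.15 log units; beyond the scatter) and a 4.3-fold higher number from compound 1 to compound 3 (0.63 log units; beyond the scatter). The earlier pair showed only a drop on going from chloro to fluoro, whereas this position now also gives a rise beyond the scatter from chloro, between two plain numbers, so the upward move does not depend on the fluoro compound as a starting point. The reading of compound 2 is a limit and not a number, and the full size of the step from it stays open: the limit of <= 3 mL/min/kg in this assay, at which 1 of the 3 values shown sits.

The compounds shown leave open whether the rise follows the sulfur or the methyl on it, a question that methoxy, with oxygen in place of sulfur, and ethylsulfanyl, with a longer chain on sulfur, would bear on directly. Also open, going by these compounds, is whether the same order of fluoro, chloro and methylsulfanyl would hold with a different amine on the shared core, since all three compounds carry the same one.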